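A few compounds are considered here, and "the series" means these few. Any claim that something is new, unique, unknown or untested is made for them only; others in the source may bear on it.

Measured so far:
compound 1, `COc1ccc(C[C@@H](O)/C=C/C=C/C(=O)N2CCN(c3ccccn3)CC2)cc1OC` — in a functional assay on HeLa cells (Homo sapiens) for antiproliferative activity, read by sulforhodamine B assay, with a stated time of 48 h (on this read-out higher numbers stand for weaker inhibition and lower numbers for stronger inhibition), compound 1 gives 23600 nM
compound 2, `COc1ccc(C[C@@H](O)/C=C/C=C/C(=O)N2CCN(c3ccccc3)CC2)cc1OC` — compound 2 gives 9750 nM
compound 3, `CCNC(=O)/C=C/C=C/[C@H](O)Cc1ccc(OC)c(OC)c1` — compound 3 gives 14600 nM

All three share a core with a hydroxyl-bearing chain ending in an amide, and they differ only in what sits on the amide. The number for compound 3 lies among those of compounds 1 and 2, and its gap to each of them falls within the scatter, so the three cannot be told apart with confidence. For the measured compounds named here, the one measured step, a 2.4-fold lower number from compound 1 to compound 2 (0.38 log units; beyond the scatter), concerns the group on the far nitrogen of a piperazine and not the amide itself.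

Compound 4, `COc1ccc(C[C@@H](O)/C=C/C=C/C(=O)N2CCCCC2)cc1OC`, carries piperidin-1-yl in place of ethylamino on a carbonyl carbon. Going by the values given here, no measured step covers this change; the values of compounds 1, 2 and 3 together show only that varying the amide substituent has so far left the numbers close together. The expected step is therefore a 1.2-fold lower number from compound 3 to compound 4 (0.09 log units; within the scatter), a change not expected to go beyond the scatter. Compound 4 is expected to give 12000 nM, within a range of 5000 nM to 30000 nM.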

Compound 4, half-maximal inhibitory concentration: 14100 nM
For compound 4 the middle estimate is 1.2-fold (0.07 log units) below the measured one, within the range that was stated.
By their numbers in this assay, from the lowest: compounds 2, 4, 3 and 1 (each within the scatter of the next, the first and the last beyond it).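

In this assay, replacing ethylamino with piperidin-1-yl on the carbonyl carbon gives a 1.0-fold lower number from compound 3 to compound 4 (0.02 log units; within the scatter), so the two compounds cannot be told apart. This holds even though the entering group brings one six-membered non-aromatic ring, has 6 heavy atoms in place of 3, and has 0 hydrogen-bond donors in place of 1, so the amide hydrogen of compound 3 is absent from compound 4. No measurement bears on why these two numbers fall so close together.

Going by these compounds, it remains open whether a morpholin-4-yl group, a longer chain on the amide nitrogen or a carboxylic acid in place of the amide would stand apart from these numbers. The hydroxyl and methoxy groups are the same in all the compounds shown, so their part in the activity also remains open.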